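The source may hold more compounds than are shown below. What is called first, only, known or untested is meant among the compounds shown, and "the series" means these compounds.

Compound 1 (`CCOc1cc(C(C)(C)C)ccc1C1=NC(c2ccc(Cl)cc2)C(c2ccc(Cl)cc2)N1C(=O)N1CCN(CCCCCCCC(=O)NO)CC1`) is the more potent of the two measured compounds in a functional assay on HCT-116 cells (Homo sapiens) for antiproliferative activity, read by CCK-8 assay, with a stated time of 72 h; a lower number here means a stronger inhibitor, a higher number a weaker inhibitor: compound 1 gives 1710 nM. Compound 2 (`CCOc1cc(C(C)(C)C)ccc1C1=NC(c2ccc(Cl)cc2)C(c2ccc(Cl)cc2)N1C(=O)NCCCCCC(=O)Nc1ccccc1N`) differs from compound 1 in several places. In this assay compound 2 gives 21800 nM, a gap from compound 1 that lies beyond the scatter. Going by the values given here, nothing else has been measured, so no single-change step is available to guide the next move.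

Among the compounds with values here, compound 3 (`CCOc1cc(C(C)(C)C)ccc1C1=NC(c2ccc(Cl)cc2)C(c2ccc(Cl)cc2)N1C(=O)N1CCN(c2ncc(C(=O)NO)cn2)CC1`) keeps the shared core of compound 1 and alters only one group: 5-(hydroxycarbamoyl)pyrimidin-2-yl in place of 7-(hydroxycarbamoyl)heptyl on an amine nitrogen in a ring. The hydroxycarbamoyl function is retained, but the heptyl chain that carried it is exchanged for a pyrimidinyl ring that carries it directly. Within the data shown here, with no comparable step among the measured compounds, the size of this change is uncertain. The step from compound 1 to compound 3 is expected to be small, perhaps a modest gain or none beyond the scatter, as a 1.2-fold lower number from compound 1 to compound 3 (0.09 log units; within the scatter). Compound 3 is therefore estimated to give 1400 nM, with a range from 350 nM to 5500 nM.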

Compound 3, half-maximal inhibitory concentration: 980 nM
For compound 3 the middle estimate is 1.4-fold (0.15 log units) above the measured one, within the range that was stated.
By their numbers in this assay, from the lowest: compounds 3 and 1 (each within the scatter of the next); then compound 2.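

In this assay, going by these compounds alone, putting 5-(hydroxycarbamoyl)pyrimidin-2-yl in place of 7-(hydroxycarbamoyl)heptyl on an amine nitrogen in a ring gives a 1.7-fold lower number from compound 1 to compound 3 (0.24 log units; within the scatter), the first single-change step. At this position of the six-membered non-aromatic ring with 2 nitrogen, a chain with no ring and a six-membered aromatic ring with 2 hetero atoms, each carrying the hydroxycarbamoyl function, therefore give values that cannot be told apart in this assay. Nothing measured on these compounds beyond this cell read-out bears on why the two groups read alike.

The compounds shown leave open whether the hydroxycarbamoyl function itself matters at this position, a question that a carboxylic acid or a primary amide on the same pyrimidine ring would address. They also leave open how a shorter alkyl chain or a pyridine ring on the same nitrogen would read, and the gap to compound 2 stays unassigned, since that compound differs from the others in several places.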